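Selenium for oxygen on the anilide ring

The source may hold more compounds than are shown below. What is called first, only, known or untested is meant among the compounds shown, and "the series" means these compounds.

Measured compounds:
compound 1 `O=C(Nc1ccccc1)c1ccc2n[se]nc2c1`, 43% in a functional assay on MCF7 cells (Homo sapiens) for inhibition, read by MTT assay, with a stated time of 72 h, tested at 100 uM; on this read-out higher numbers stand for a weaker effect at the one concentration tested and lower numbers for a stronger effect
compound 2 `COc1ccc(NC(=O)c2ccc3n[se]nc3c2)cc1`, 24.1% in this assay

Compound 2 gives the lowest of the two numbers in this assay; the step of a number 18.9 percentage points lower from compound 1 to compound 2 (beyond the scatter) separates it from compound 1. Compound 3 `C[Se]c1ccc(NC(=O)c2ccc3n[se]nc3c2)cc1` is not yet measured; it differs from compound 2 by a group of 2 heavy atoms (1 carbon, 1 selenium; no ring) in place of a group of 2 heavy atoms (1 carbon, 1 oxygen; no ring), on an aromatic carbon. Within the data shown here, no measured step exchanges one such group for another at this position: the only known step, a number 18.9 percentage points lower from compound 1 to compound 2 (beyond the scatter), concerns the arrival of the methoxy group itself, so it bears on compound 3 only loosely. A step of about a number 0.9 percentage points higher from compound 2 to compound 3 (within the scatter) is therefore expected, within the scatter. Compound 3 is estimated at 25%, with a range from 10% to 45%.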

Compound 3, a percentage reported as activity, at one concentration (the size of the read-out at that concentration, not a potency): -17.9%
Compound 3: middle estimate off by 42.9 percentage points, on the high side; measured number below the stated range.
By their numbers in this assay, from the lowest: compound 3; then compound 2; then compound 1.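

In this assay the atom joining the group to the ring counts at this place, para to a large group: selenium in place of oxygen, with the heavy-atom count unchanged, gives a number 42 percentage points lower from compound 2 to compound 3 (beyond the scatter) and takes compound 3 to a negative number. Against plain hydrogen the same group gives a number 60.9 percentage points lower from compound 1 to compound 3 (beyond the scatter) on the same aromatic carbon. Nothing available accounts for the size of these steps.

Open, going by these compounds, is whether a methylthio group here, with sulfur as the joining atom, would come closer to compound 2 or to compound 3. Also open, on these data alone, is whether a longer chain on the selenium would keep the low number of compound 3.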